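Adding a Nitro Group to the Chloro Analogue

This account rests on a few compounds, and the source may have more. Where it says the series, first, only, none or still open, it means among the compounds named here.

Measured compounds:
compound 1 `COc1cc(NC(=O)c2ccc(Cl)cc2)ccc1NS(=O)(=O)C(F)(F)F`: 108000 nM
compound 2 `COc1cc(NC(=O)c2ccc(Cl)c([N+](=O)[O-])c2)ccc1NS(=O)(=O)C(F)(F)F`: > 250000 nM (a limit, not a number)
compound 3 `O=C(Nc1ccc(NS(=O)(=O)C(F)(F)F)c(Cl)c1)c1ccc(Cl)cc1`: 47200 nM

All three were tested in an ADME assay on RAW264.7 cells (Mus musculus) for cytotoxicity, read by MTT assay, with a stated time of 48 h; on this read-out lower numbers stand for stronger inhibition and higher numbers for weaker inhibition. Compound 1 and compound 2 differ in one place: nitro in place of hydrogen on an aromatic carbon. In this assay that change gave an at least 2.3-fold higher number from compound 1 to compound 2 (0.36 log units; beyond the scatter). The value of compound 2 is a limit of the assay rather than a number (the limit of > 250000 nM in this assay, at which 1 of the 3 values shown sits). Compound 3 differs from compound 1 in the core: chloro in place of methoxy on an aromatic carbon. This change gave a 2.3-fold lower number from compound 1 to compound 3 (0.36 log units; beyond the scatter), so compound 3 has the lowest number among the two compounds with a number.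

Compound 4, `O=C(Nc1ccc(NS(=O)(=O)C(F)(F)F)c(Cl)c1)c1ccc(Cl)c([N+](=O)[O-])c1`, has not yet been measured. It differs from compound 3 by nitro in place of hydrogen on an aromatic carbon. The surroundings of the new group are described in the same words as for the change from compound 1 to compound 2, so this is the same change made on the other core. Going by the values given here, the earlier step, an at least 2.3-fold higher number from compound 1 to compound 2 (0.36 log units; beyond the scatter), is the only guide to what to expect. A step of similar size and direction is expected here, a 2.8-fold higher number from compound 3 to compound 4 (0.44 log units; beyond the scatter). Compound 4 is therefore estimated at 130000 nM, plausibly between 60000 nM and 300000 nM, and it may also reach only a limit.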

Compound 4, half-maximal inhibitory concentration: 31700 nM
Beside the measured number, compound 4's estimate is 4.1-fold (0.61 log units) above it, and the stated range ends above it.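

In this assay, the nitro group does not carry over cleanly from one core to the other, since on the core of compound 3 it gives a 1.5-fold lower number from compound 3 to compound 4 (0.17 log units; within the scatter), and the two steps differ: the same change on two cores in this assay, an at least 2.3-fold higher number (0.36 log units; beyond the scatter) from compound 1 to compound 2 and a 1.5-fold lower number (0.17 log units; within the scatter) from compound 3 to compound 4, at least 3.4-fold (0.53 log units) apart, beyond the scatter of two such steps
Chloro in place of methoxy lowers the number on both cores, but the size of that step is not the same, as the new step of an at least 7.8-fold lower number from compound 2 to compound 4 (0.89 log units; beyond the scatter) shows when set beside the earlier one: the same change on two cores in this assay, a 2.3-fold lower number (0.36 log units; beyond the scatter) from compound 1 to compound 3 and an at least 7.8-fold lower number (0.89 log units; beyond the scatter) from compound 2 to compound 4, at least 3.4-fold (0.53 log units) apart, beyond the scatter of two such steps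
Compound 2 gives > 250000 nM, which is a limit and not a number, so the steps that touch it have only a bound on their size, and a single pair of cores cannot show why the nitro step failed to carry over.

The compounds shown leave open whether the nitro step would shift again with another group in the place of the chloro or methoxy, such as a methyl group or a nitrile. They also leave open whether an amine or a carboxylic acid in place of the nitro group would follow the same course on either core.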